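This account rests on a few compounds, and the source may have more. Where it says the series, first, only, none or still open, it means among the compounds named here.

Measured in a functional assay on the whole organism (strain Sprague-Dawley) for inhibition, with Rattus norvegicus as the target, with a stated time of 10 min; a higher number here means that more compound is needed for the effect, a lower number that less compound is needed:
- compound 1 `CCOC(=O)c1cnc(-c2ccccc2Cl)[nH]c1=O`: 5 mg/kg
- compound 2 `CCOC(=O)c1cnc(-c2ccccc2OC(C)C)[nH]c1=O`: 2 mg/kg
- compound 3 `CCOC(=O)c1cnc(-c2ccccc2OCc2ccccc2)[nH]c1=O`: > 5 mg/kg, a limit and not a number

Compound 3 is known only through a limit, (the limit of > 5 mg/kg in this assay, at which 1 of the 3 values shown sits).

The next compound, compound 4 `CCOC(=O)c1cnc(-c2ccccc2SC)[nH]c1=O`, carries methylsulfanyl in place of benzyloxy on an aromatic carbon, ortho to a large group: methylsulfanyl in place of benzyloxy on an aromatic carbon.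

Within the data shown here, no measured step makes this exact exchange, but three steps change the same place. The closest is an at least 2.5-fold higher number from compound 2 to compound 3 (0.39 log units; beyond the scatter), with benzyl in place of isopropyl on the oxygen. Alongside it stand a 2.5-fold lower number from compound 1 to compound 2 (0.40 log units; beyond the scatter), with isopropoxy in place of chloro, and a number no lower from compound 1 to compound 3 (the limit leaves the size open), with benzyloxy in place of chloro, whose size stays open. Of the three measured groups, only benzyloxy has a ring, and methylsulfanyl has none. Among the measured compounds shown here, the expectation for compound 4 therefore leans on compound 1 at 5 mg/kg and compound 2 at 2 mg/kg, with only three compounds behind it.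

A lower number in this assay is expected, of modest size, although the limit leaves the starting point open: the expected change is an at least 1.6-fold lower number from compound 3 to compound 4 (0.22 log units; that floor lies within the scatter).

For compound 4 the estimated value is 3 mg/kg, with an expected range of 1 mg/kg to 8 mg/kg.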

Compound 4, dose for 50% inhibition: > 25 mg/kg
Compound 4 gave a limit, no number; the forecaster's own chance of this, stated with the estimate: 15%; at least 8.3-fold (0.92 log units) between middle value and limit.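

Compound 4 is known only through a limit in this assay: the limit of > 25 mg/kg in this assay, at which 1 of the 4 values shown sits.

Methylsulfanyl in place of isopropoxy gives an at least 12-fold higher number from compound 2 to compound 4 (1.09 log units; beyond the scatter), and methylsulfanyl in place of chloro gives an at least 5.0-fold higher number from compound 1 to compound 4 (0.69 log units; beyond the scatter). Benzyloxy is thus no longer the only group at this place, on an aromatic carbon ortho to a large group, that leaves the number high: methylsulfanyl has no ring and fewer heavy atoms, so among these four compounds neither the lack of a ring nor a small group is enough to keep the number low, and the step between compound 3 and compound 4 cannot be read, since both are limits.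

Methoxy at this place, with oxygen in place of the sulfur of methylsulfanyl, would show whether the loss follows the sulfur or the short chain, and the compounds shown hold no such pair. Going by these compounds, the actual values of compound 3 and compound 4 also stay open, so the order of benzyloxy and methylsulfanyl at this place remains unknown.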